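The compounds below may be only part of what the source reports. "The series", "measured", "known", "first", "only" and "open" are said of these compounds alone.

Series values in a functional assay on MCF7 cells (Homo sapiens) for cytotoxicity, read by MTT assay, with a stated time of 72 h; on this read-out lower numbers stand for stronger inhibition and higher numbers for weaker inhibition:
- Compound 1 `COc1ccc(/C=C2\CCC/C(=C\c3ccccc3Br)C2=O)cc1OC`: 9500 nM
- Compound 2 `COc1cccc(/C=C2\CCC/C(=C\c3ccc(OC)c(OC)c3)C2=O)c1`: 4600 nM
- Compound 3 `COc1ccc(/C=C2\CCC/C(=C\c3ccc(O)cc3)C2=O)cc1OC`: 17000 nM

Compound 3 lies within the scatter of compound 1, while compound 2 gives a clearly lower number. Compound 4 `COc1ccc(/C=C2\CCC/C(=C\c3cc(Cl)cc(Cl)c3)C2=O)cc1OC` has 3,5-dichlorophenyl in place of 4-hydroxyphenyl on a double-bonded chain carbon bound to a double-bonded ring carbon.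

Two measured steps at this place bear on the change. The first is a 1.8-fold higher number from compound 1 to compound 3 (0.25 log units; within the scatter), and the second is a 3.7-fold higher number from compound 2 to compound 3 (0.57 log units; beyond the scatter). Neither includes 3,5-dichlorophenyl, so the read-across is loose. For the measured compounds named here, compound 1 carries the only halogen-bearing group measured so far, and its step to compound 3 stays within the scatter. Compound 2 shows that a modest gap at this place is possible.

Going by the values given here, a small to modest move towards a lower number is therefore expected, with no large step anticipated. The expected step is a 2.1-fold lower number from compound 3 to compound 4 (0.33 log units; beyond the scatter). Compound 4 is estimated at 8000 nM, with an expected range of 2500 nM to 20000 nM.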

Compound 4, half-maximal inhibitory concentration: 3800 nM
Compound 4: middle estimate off by 2.1-fold (0.32 log units), on the high side, within the range that was stated.
By their numbers in this assay, from the lowest: compounds 4 and 2 (each within the scatter of the next); then compounds 1 and 3 (each within the scatter of the next).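

In this assay, replacing 4-hydroxyphenyl with 3,5-dichlorophenyl moves the number clearly at this position (a 4.5-fold lower number from compound 3 to compound 4 (0.65 log units; beyond the scatter)), so a halogen-bearing group here is not tied to the level of compound 1. The two halogen-bearing groups now separate (a 2.5-fold lower number from compound 1 to compound 4 (0.40 log units; beyond the scatter)), which shows that the presence of halogen alone does not set the number in this small set. Compound 4 and compound 2 sit together (a 1.2-fold lower number from compound 2 to compound 4 (0.08 log units; within the scatter)), so 3,5-dichlorophenyl and 3-methoxyphenyl cannot be told apart here, although their groups share no substituent.

On these data alone, whether an amine or a carboxylic acid on the phenyl ring at this place would shift the number further remains open. Nothing available accounts for the gaps among these groups.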